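From aryl amide to tert-butyl amide at the ring nitrogen

The compounds below may be only part of what the source reports. "The series", "measured", "known", "first", "only" and "open" are said of these compounds alone.

Compound 1 `Fc1ccc(CN2CCC(NCCSC(c3ccc(F)cc3)c3ccc(F)cc3)CC2)cc1`: 980 nM in an assay on membranes from HEK293 cells for displacement of a labelled ligand from D(4) dopamine receptor (Homo sapiens), read by scintillation counting, with a stated time of 60 min; on this read-out lower numbers stand for stronger inhibition and higher numbers for weaker inhibition
Compound 2 `OC(Cc1ccccc1)CN1CCC(NCCSC(c2ccc(F)cc2)c2ccc(F)cc2)CC1`: 2200 nM
Compound 3 `O=C(c1ccc(F)cc1)N1CCC(NCCSC(c2ccc(F)cc2)c2ccc(F)cc2)CC1`: 9020 nM

All three compounds share the same core and differ only in the group carried by the amine nitrogen in the ring. Compound 3 has the highest number of the three, which on this read-out means the weakest binding: the change a 9.2-fold higher number from compound 1 to compound 3 (0.96 log units; beyond the scatter) and the change a 4.1-fold higher number from compound 2 to compound 3 (0.61 log units; beyond the scatter) both move in that direction.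

Compound 4 `CC(C)(C)C(=O)N1CCC(NCCSC(c2ccc(F)cc2)c2ccc(F)cc2)CC1` differs from compound 3 by tert-butyl in place of 4-fluorophenyl on a carbonyl carbon. Among the compounds with values here, none of the measured steps alters the group on a carbonyl carbon, so none bears directly on this change; they only show that the amide compound 3 sits at the weak end of the series. Without a closer precedent, a further modest rise in the number is expected, which in this assay would be the step of a 1.7-fold higher number from compound 3 to compound 4 (0.22 log units; within the scatter). The estimate for compound 4 is therefore 15000 nM, with a range from 5000 nM to 45000 nM.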

Compound 4, inhibition constant: 11900 nM
Estimate against measurement, compound 4: 1.3-fold (0.10 log units) above, and the stated range covers the measured number.
By their numbers in this assay, from the lowest: compound 1; then compound 2; then compounds 3 and 4 (each within the scatter of the next).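

Replacing the 4-fluorophenyl on the carbonyl carbon with tert-butyl removes the aromatic ring, yet in this assay the result is a 1.3-fold higher number from compound 3 to compound 4 (0.12 log units; within the scatter), so this pair shows no measurable effect of the swap. Compound 4 shares the weak end of the series with compound 3, and the gap to the compounds without a carbonyl on the ring nitrogen remains, with a 5.4-fold higher number from compound 2 to compound 4 (0.73 log units; beyond the scatter) and a 12-fold higher number from compound 1 to compound 4 (1.08 log units; beyond the scatter). No supporting data explain these differences.

The compounds shown do not reveal whether any group on the carbonyl carbon can bring the number down, for example a methyl, a longer chain or an amine. Nor do they show how tert-butyl behaves directly on the amine nitrogen in the ring, with no carbonyl present.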